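The compounds below may be only part of what the source reports. "The series", "measured", "known", "first", "only" and "open" are said of these compounds alone.

In a functional assay on HeLa cells (Homo sapiens) for antiproliferative activity, read by CCK-8 assay, with a stated time of 72 h (on this read-out higher numbers stand for weaker inhibition and lower numbers for stronger inhibition), two close analogues sharing one core have been measured. Compound 1 `COc1ccccc1C(=O)Nc1cccc(-c2oc3cc(-c4ccc(F)cc4)ccc3c(=O)c2O)c1` gives 14100 nM, and compound 2 `Cc1ccccc1C(=O)Nc1cccc(-c2oc3cc(-c4ccc(F)cc4)ccc3c(=O)c2O)c1` gives 11900 nM. Among the compounds with values here, the only step between them, a 1.2-fold lower number from compound 1 to compound 2 (0.07 log units; within the scatter), comes from methyl in place of methoxy on an aromatic carbon. On these two numbers compound 2 stands with the lower value, but its distance from compound 1 is within the scatter, so the two cannot be told apart.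

Compound 3 `Cc1cccc(C(=O)Nc2cccc(-c3oc4cc(-c5ccc(F)cc5)ccc4c(=O)c3O)c2)c1` has not been measured. It differs from compound 2 by 3-methylphenyl in place of 2-methylphenyl on a carbonyl carbon; the same atoms are present and only their arrangement within the methylphenyl group changes. Within the data shown here, no measured step covers a shift of a methyl from one position of this ring to another. Among the measured compounds shown here, the single step available, from the methoxy to the methyl analogue, stayed within the scatter, and nothing here suggests that a positional move of the methyl would behave differently. Compound 3 is therefore expected to show a 1.0-fold higher number from compound 2 to compound 3 (0.00 log units; within the scatter), no change beyond the scatter. The estimate for compound 3 is 12000 nM, with a range of 5000 nM to 30000 nM.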

Compound 3, half-maximal inhibitory concentration: 6650 nM
Compound 3: middle estimate off by 1.8-fold (0.26 log units), on the high side; the range from low to high includes it.
By their numbers in this assay, from the lowest: compounds 3, 2 and 1 (each within the scatter of the next, the first and the last beyond it).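

In this assay, moving the methyl from 2-methylphenyl to 3-methylphenyl on the carbonyl carbon gives a 1.8-fold lower number from compound 2 to compound 3 (0.25 log units; within the scatter), so this rearrangement of the same atoms cannot be separated from the scatter on its own. Within the data shown here, the comparison with the methoxy analogue says more: 3-methylphenyl in place of 2-methoxyphenyl gives a 2.1-fold lower number from compound 1 to compound 3 (0.33 log units; beyond the scatter), the first step at this position to pass beyond the scatter, although only modestly, while compound 2 remains within the scatter of both compound 1 and compound 3. This position therefore shows a small but detectable response to the aryl group on the carbonyl carbon, and no measurement here explains that response.

The compounds shown leave open whether a methoxy group carried as 3-methoxyphenyl would match 3-methylphenyl, which would help separate the effect of the group from that of its placement on the ring. They also leave open how this position would respond to a larger change, such as an ethyl group, an amine or a carboxylic acid on the phenyl ring, or a pyridine ring in place of it.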